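This account rests on a few compounds, and the source may have more. Where it says the series, first, only, none or still open, it means among the compounds named here.

In a functional assay on K562 cells (Homo sapiens) for cytotoxicity, read by MTT assay, with a stated time of 48 h (a lower number here means a stronger inhibitor, a higher number a weaker inhibitor), compound 1 (`COc1cc([C@@H]2C[C@]2(CO)C(=O)NCc2ccc(C)cc2)cc(OC)c1OC`) gives > 100000 nM, a limit of the assay and not a number. Compound 2 (`CCOC(=O)[C@]1(C(=O)NCc2ccc(C)cc2)C[C@H]1c1cc(OC)c(OC)c(OC)c1`) gives > 100000 nM, likewise a limit, and it stands at the limit of > 100000 nM in this assay, at which 2 of the 2 values shown sit. Within the data shown here, the one measured step, a step that the two limits leave unreadable from compound 1 to compound 2, offers no size to carry forward. Compound 3 (`CCOC(=O)[C@]1(C(=O)NCc2ccc(C)cc2)C[C@@H]1c1cc(OC)c(OC)c(OC)c1`) departs from compound 2 only thus: the two compounds have the same atoms and bonds and differ only in configuration as drawn: 1 of 2 stereo elements differ; a stereocentre at a saturated ring carbon is drawn S in compound 2 and R in compound 3. Among the measured compounds shown here, no measured step tests configuration, so no direction can be derived, and a result close to the limit remains the expectation. Compound 3 is expected at 100000 nM, with an estimated range of 30000 nM to 150000 nM. The expected change is a number no higher from compound 2 to compound 3 (the limit leaves the size open).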

Compound 3, half-maximal inhibitory concentration: 20400 nM
The estimate for compound 3 lay 4.9-fold (0.69 log units) above the measured number, and the stated range ends above it.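

In this assay, the configuration at this saturated ring carbon, drawn R in place of S, gives an at least 4.9-fold lower number from compound 2 to compound 3 (0.69 log units; beyond the scatter). Among these compounds, this is the first readable step, as the step between compound 1 and compound 2 cannot be read. The shift can be assigned to configuration alone: the fact that compounds 2 and 3 differ only in the configuration as drawn

Open, from the compounds shown here alone, is how a carboxylic acid in place of the ethoxycarbonyl would read with the configuration of compound 3. Also open, going by these compounds, is what the second stereo element, the same in compound 2 and compound 3, contributes.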